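A few compounds are considered here, and "the series" means these few. Any claim that something is new, unique, unknown or untested is made for them only; others in the source may bear on it.

Compounds measured in a toxicity assay on NIH3T3 cells (Mus musculus) for cytotoxicity, read by resazurin assay; on this read-out lower numbers stand for an effect already at smaller amounts and higher numbers for an effect only at larger amounts of compound:
Compound 1 `COC(=O)c1ccc(NCc2cncn2Cc2ccccc2N)cc1-c1ccccc1`: 25000 nM
Compound 2 `COC(=O)c1ccc(NCc2cncn2Cc2ccc(C(C)(C)C)cc2)cc1-c1ccccc1`: "not determined" (no result reported)
Compound 3 `COC(=O)c1ccc(NCc2cncn2Cc2cccc(C#N)c2)cc1-c1ccccc1`: > 10000 nM

Compound 3 stands at > 10000 nM in this assay, and this is a limit of the assay, not a number. Compound 2 adds no usable result. The next compound is compound 4 `COC(=O)c1ccc(NCc2cncn2Cc2ccc(F)cc2F)cc1-c1ccccc1`, with 2,4-difluorophenyl in place of 3-cyanophenyl on a saturated chain carbon bound to an aromatic nitrogen. For the measured compounds named here, only one measured step bears on this place, a step that the limit leaves unreadable from compound 1 to compound 3, so it gives no size to carry over. Going by the values given here, the only firm number is that compound 1 gives 25000 nM, so a large change is not expected, and no direction can be argued. A step beyond the usual scatter is therefore not expected in this assay. A reported limit is also a likely outcome, given (the limit of > 10000 nM in this assay, at which 1 of the 3 values shown sits). The expected step is a step that the limit leaves unreadable from compound 3 to compound 4. Compound 4 is estimated at 20000 nM, with an expected range from 8000 nM to 50000 nM.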

Compound 4, half-maximal effective concentration: > 1000 nM
Compound 4: a limit, no number; the forecaster's own chance of this, stated with the estimate: 55%; the middle value is on the limit's open side.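

In this assay compound 4 gives > 1000 nM, which is a limit and not a number. For the compounds shown here, neither the step to compound 4 from compound 3 nor the one from compound 1 can be read. The compounds shown leave open whether swapping the group on the saturated chain carbon changes cytotoxicity at all.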